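Phenoxymethyl to phenyl: compound 3 to compound 4

The source may hold more compounds than are shown below. What is called first, only, known or untested is meant among the compounds shown, and "the series" means these compounds.

Values in a functional assay on RAW264.7 cells (Mus musculus) for inhibition, read by Griess assay, with stated times of 1 h and 24 h; a higher number here means a weaker inhibitor, a lower number a stronger inhibitor:
- compound 1 `COc1ccc(C(O)C2OC(=O)c3c(OC)cc(OC)cc32)cc1`: > 10000 nM
- compound 2 `COCCCOc1ccc(C(O)C2OC(=O)c3c(OC)cc(OC)cc32)cc1`: 1260 nM
- compound 3 `COc1cc(OC)c2c(c1)C(C(O)c1ccc(OCCOc3ccccc3)cc1)OC2=O`: > 10000 nM

Compound 3 gives only a limit, > 10000 nM. Compound 1 also gives only a limit, > 10000 nM. Compound 4 `COc1cc(OC)c2c(c1)C(C(O)c1ccc(OCc3ccccc3)cc1)OC2=O` differs from compound 3 as follows: phenyl in place of phenoxymethyl on a saturated chain carbon bound to an oxygen on an aromatic ring. The relevant steps are an at least 7.9-fold lower number from compound 1 to compound 2 (0.89 log units; beyond the scatter) and an at least 7.9-fold higher number from compound 2 to compound 3 (0.89 log units; beyond the scatter). The second shows a higher number with the ring-bearing chain of compound 3. The step that the two limits leave unreadable from compound 1 to compound 3 gives no size. Compound 4 keeps an aromatic ring on a shorter chain, so only a small move towards a lower number is expected in this assay, possibly none beyond the scatter. The expected change is an at least 1.6-fold lower number from compound 3 to compound 4 (0.22 log units; that floor lies within the scatter). For compound 4 the estimated value is 6000 nM, with an expected range of 1500 nM to 25000 nM.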

Compound 4, half-maximal inhibitory concentration: > 10000 nM
Compound 4: a limit, no number; the forecaster's own chance of this, stated with the estimate: 50%; middle value at least 1.6-fold (0.22 log units) from the limit.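

In this assay, the benzyl chain, set against the methoxy-ended chain, gives an at least 7.9-fold higher number from compound 2 to compound 4 (0.89 log units; beyond the scatter). A terminal aromatic ring therefore stays short of the only measured number in the series at both chain lengths shown, the 2-phenoxyethyl of compound 3 and the benzyl of compound 4. The steps from compound 3 and compound 1 to compound 4 cannot be read, since both ends are limits, and most of the series sits at that ceiling: the limit of > 10000 nM in this assay, at which 3 of the 4 values shown sit.

Any ranking among compound 1, compound 3 and compound 4 stays open. Also open, from the compounds shown here alone, is whether a longer ether chain, a terminal amine or a carboxylic acid at this position would improve on compound 2.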